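This account rests on a few compounds, and the source may have more. Where it says the series, first, only, none or still open, it means among the compounds named here.

In a functional assay on NTUB1 cells (Homo sapiens) for cytotoxicity, read by MTT assay, with a stated time of 72 h (on this read-out lower numbers stand for stronger inhibition and higher numbers for weaker inhibition), compound 1 `COC(=O)c1ccc(/C=C/C(=O)c2cc(OC)ccc2OC)cc1` gives 3510 nM, the highest of the three numbers recorded, though its gaps to the other two lie within the scatter. Compound 2 `CNC(=O)c1ccc(/C=C/C(=O)c2cc(OC)ccc2OC)cc1` gives 2200 nM and compound 3 `CCN(CC)C(=O)c1ccc(/C=C/C(=O)c2cc(OC)ccc2OC)cc1` gives 2690 nM. Compound 4 `COc1ccc(OC)c(C(=O)/C=C/c2ccc(C(=O)N3CCCC3)cc2)c1` differs from compound 1 by pyrrolidin-1-yl in place of methoxy on a carbonyl carbon. The precedents that bear on it are the two earlier replacements of the methoxy on that carbonyl carbon: a 1.6-fold lower number from compound 1 to compound 2 (0.20 log units; within the scatter) and a 1.3-fold lower number from compound 1 to compound 3 (0.12 log units; within the scatter), each within the scatter. On that record the step to compound 4 is expected to stay within the scatter, leaning if anywhere toward a lower number, a 1.4-fold lower number from compound 1 to compound 4 (0.15 log units; within the scatter). Compound 4 is therefore estimated at 2500 nM, within a range from 1200 nM to 5200 nM.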

Compound 4, half-maximal inhibitory concentration: 1260 nM
Compound 4: middle estimate off by 2.0-fold (0.30 log units), on the high side, and the stated range covers the measured number.
By their numbers in this assay, from the lowest: compounds 4, 2, 3 and 1 (each within the scatter of the next, the first and the last beyond it).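

Among the replacements of methoxy on this carbonyl carbon, pyrrolidin-1-yl is the only one shown to move the number beyond the scatter in this assay (a 2.8-fold lower number from compound 1 to compound 4 (0.44 log units; beyond the scatter)). It also separates from the open-chain diethylamino group (a 2.1-fold lower number from compound 3 to compound 4 (0.33 log units; beyond the scatter)), but not from methylamino (a 1.7-fold lower number from compound 2 to compound 4 (0.24 log units; within the scatter)). No measurement here explains this difference.

As far as these compounds go, it remains open whether another ring on this carbonyl carbon, such as piperidin-1-yl or morpholin-4-yl, would give a number like that of compound 4. A free carboxylic acid at this place also remains untested by the compounds shown.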